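Working notes on amide-end variation in one series

The source may hold more compounds than are shown below. What is called first, only, known or untested is meant among the compounds shown, and "the series" means these compounds.

Measured so far:
compound 1 `COc1ccc(-n2c(SC(C)C(=O)Nc3cc(Br)ccc3Br)nc3ccccc32)cc1` — "not determined" (no result reported) in an ADME assay on Vero cells (Chlorocebus sabaeus) for cytotoxicity, read by MTT assay, with a stated time of 24 h; a higher number here means that more compound is tolerated, a lower number that less compound is tolerated
compound 2 `CC(Sc1nc2ccccc2n1-c1ccc(F)cc1)C(=O)Nc1ncc(Cl)cc1Cl` — 5900 nM

Compound 1 has no number in this assay, so its standing on tolerated concentration cannot be placed. Within the data shown here, the only number in the set comes from compound 2, which gives 5900 nM.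

Compound 3 `COc1ccc(-n2c(SC(C)C(=O)Nc3cc(C)nn3C)nc3ccccc32)cc1` differs from compound 1 in one place: 1,3-dimethyl-1H-pyrazol-5-yl in place of 2,5-dibromophenyl on an amide-type nitrogen. Among the measured compounds shown here, no measured pair shows what this change does, and compound 1 itself is unmeasured, so no direction can be read; no step beyond the usual scatter is assumed. Compound 3 is expected to give about 8000 nM, with the estimate ranging from 2000 nM to 40000 nM.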

Compound 3, half-maximal cytotoxic concentration: 75000 nM
Estimate against measurement, compound 3: 9.4-fold (0.97 log units) below; measured number outside the range, above it.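

No step can be read between compound 1 and compound 3, as compound 1 gives "not determined" (no result reported) in this assay here. The compounds shown leave open what replacing 2,5-dibromophenyl with 1,3-dimethyl-1H-pyrazol-5-yl does to the tolerated concentration. No evidence at hand bears on this result.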